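From phenyl to benzofuranyl on the shared core

The compounds below may be only part of what the source reports. "The series", "measured", "known", "first", "only" and "open" are said of these compounds alone.

Values in a functional assay on HCT-116 cells (Homo sapiens), read by MTT assay, with a stated time of 72 h; a higher number here means a weaker inhibitor, a lower number a stronger inhibitor:
- Compound 1 `O=c1[nH]cnc2c1c(-c1cc3ccccc3o1)cn2[C@@H]1O[C@H](CO)[C@@H](O)[C@H]1O`: > 20000 nM, a limit
- Compound 2 `Nc1nc2c(c(-c3ccoc3)cn2[C@@H]2O[C@H](CO)[C@@H](O)[C@H]2O)c(=O)[nH]1`: 17600 nM
- Compound 3 `Nc1nc2c(c(-c3ccccc3)cn2[C@@H]2O[C@H](CO)[C@@H](O)[C@H]2O)c(=O)[nH]1`: > 20000 nM, a limit
- Compound 4 `Nc1nc2c(c(-c3cc4ccccc4o3)cn2[C@@H]2O[C@H](CO)[C@@H](O)[C@H]2O)c(=O)[nH]1`: not yet measured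

Compound 3 stands at > 20000 nM, which is a limit and not a number. The series crowds one end of the scale, with the limit of > 20000 nM in this assay, at which 2 of the 3 values shown sit. Compound 4 differs from compound 3 by 1-benzofuran-2-yl in place of phenyl on an aromatic carbon. Among the measured compounds shown here, the one measured step that bears on this change is an at least 1.1-fold higher number from compound 2 to compound 3 (0.05 log units; that floor lies within the scatter). Compound 1, with 1-benzofuran-2-yl on a related core, gives > 20000 nM, also a limit. No step beyond the scatter is therefore expected in this assay, in either direction. The expected step is a number no higher from compound 3 to compound 4 (the limit leaves the size open). For compound 4 the estimated value is 20000 nM, with an expected range from 9000 nM to 40000 nM.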

Compound 4, half-maximal inhibitory concentration: > 100000 nM
Compound 4: only a limit was reported; the forecaster's own chance of this, stated with the estimate: 70%; at least 5.0-fold (0.69 log units) between middle value and limit.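

In this assay, among the compounds shown here, 1-benzofuran-2-yl on this aromatic carbon gives the first step at this position that lies beyond the scatter: an at least 5.6-fold higher number from compound 2 to compound 4 (0.75 log units; beyond the scatter). On the amino-bearing core, then, furan-3-yl is the better of these two groups. The steps from compound 3 to compound 4 and from compound 1 to compound 4 cannot be read, since each joins two limits.

From the compounds shown here alone, whether an aminomethyl group or a carboxylic acid on this carbon would give a readable value stays open. So does what the amino group on the core contributes when 1-benzofuran-2-yl is present.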